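This account rests on a few compounds, and the source may have more. Where it says the series, first, only, none or still open, it means among the compounds named here.

Compound 1 `COc1cc(C)cc(-c2c(-c3ccnc(-c4ccc(C(C)=O)cc4)c3)cnn2CC#N)c1` carries an acetyl group on its outer phenyl ring. In a functional assay on HCT-15 cells (Homo sapiens) for inhibition, read by sulforhodamine B assay, with a stated time of 48 h (on this read-out lower numbers stand for stronger inhibition of growth and higher numbers for weaker inhibition of growth), compound 1 gives > 100000 nM, which is a limit of the assay rather than a number. Compound 2 `COc1cc(C)cc(-c2nn(CC#N)cc2-c2ccc(-c3cccc(C(C)=O)c3)nc2)c1` gives > 100000 nM in this assay, again only a limit. Compound 3 `Cc1cc(O)cc(-c2nn(CC#N)cc2-c2ccnc(-c3ccc(N(C)C)cc3)c2)c1`, which instead carries a dimethylamino group, gives 18200 nM in this assay. Two of the three values shown therefore sit at the limit of > 100000 nM in this assay, at which 2 of the 3 values shown sit. Compound 4 `COc1cc(C)cc(-c2c(-c3ccnc(-c4ccc(N(C)C)cc4)c3)cnn2CC#N)c1` differs from compound 1 by dimethylamino in place of acetyl on an aromatic carbon. For the measured compounds named here, no measured pair shows this change directly. The step from compound 1 to compound 4 is expected to run toward stronger inhibition, an at least 3.3-fold lower number from compound 1 to compound 4 (0.52 log units; beyond the scatter). Compound 4 is expected to give about 30000 nM, with a range from 8000 nM to 120000 nM.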

Compound 4, concentration for total growth inhibition: > 100000 nM
Compound 4: only a limit was reported; the forecaster's own chance of this, stated with the estimate: 35%; middle value at least 3.3-fold (0.52 log units) from the limit.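

Compound 1 and compound 4 both reach only a limit of the assay, so the change from acetyl to dimethylamino gives no readable step: the limit of > 100000 nM in this assay, at which 3 of the 4 values shown sit. As far as these compounds go, whether this change alters growth inhibition at all in this assay stays open.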